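Notes on compounds 1 to 4: tert-butyl in place of phenyl

A few compounds are considered here, and "the series" means these few. Any claim that something is new, unique, unknown or untested is made for them only; others in the source may bear on it.

Three compounds have numbers in a functional assay on HPAC cells (Homo sapiens) for inhibition, read by MTT assay, with a stated time of 72 h; a lower number here means a stronger inhibitor of growth, a higher number a weaker inhibitor of growth. Compound 1 `CC(C)(C)c1ccc(CNCCCNS(=O)(=O)c2cc(C(F)(F)F)cc(C(F)(F)F)c2)cc1` gives 2300 nM. Compound 2 `O=S(=O)(NCCNCc1ccc(-c2ccccc2)cc1)c1cc(C(F)(F)F)cc(C(F)(F)F)c1` gives 2800 nM, and compound 3 `O=S(=O)(NCCCNCc1ccc(-c2ccccc2)cc1)c1cc(C(F)(F)F)cc(C(F)(F)F)c1` gives 2700 nM. All three numbers lie within the usual scatter of one another, so no order among them is claimed. The difference between the cores of compound 2 and compound 3 is not broken down here.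

One structural change recurs in the set. From compound 3 to compound 1 the change is tert-butyl in place of phenyl on an aromatic carbon, and the measured step is a 1.2-fold lower number from compound 3 to compound 1 (0.07 log units; within the scatter). Compound 4 `CC(C)(C)c1ccc(CNCCNS(=O)(=O)c2cc(C(F)(F)F)cc(C(F)(F)F)c2)cc1` is not yet measured; it arises from compound 2 by tert-butyl in place of phenyl on an aromatic carbon, the same change at the same place.

Among the measured compounds shown here, the expectation for compound 4 rests on the single measured instance of this change: because the step of a 1.2-fold lower number from compound 3 to compound 1 (0.07 log units; within the scatter) lies within the scatter, the step is expected to be about as small, a 1.2-fold lower number from compound 2 to compound 4 (0.07 log units; within the scatter). Compound 4 is therefore expected to give about 2400 nM in this assay, with an expected range from 1200 nM to 4800 nM.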

Compound 4, concentration for 50% growth inhibition: 14000 nM
Compound 4: the middle estimate sits 5.8-fold (0.77 log units) below what was measured; measured number above the stated range.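

In this assay tert-butyl in place of phenyl on an aromatic carbon gives a 5.0-fold higher number from compound 2 to compound 4 (0.70 log units; beyond the scatter) on this second core, so the step measured on the first core did not carry over. Within these four compounds, the size of the step depends on the core that carries it: the same change on two cores in this assay, a 1.2-fold lower number (0.07 log units; within the scatter) from compound 3 to compound 1 and a 5.0-fold higher number (0.70 log units; beyond the scatter) from compound 2 to compound 4, 5.9-fold (0.77 log units) apart, beyond the scatter of two such steps. This rests on one pair of steps and shows that a step from one core is an unsafe guide to the other here, but it does not show which difference between the cores matters, why the steps part, or how the change would behave on any further core.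

The compounds shown leave open whether other groups at the same place, such as cyclohexyl, isopropyl or methoxy, would follow the phenyl or the tert-butyl compounds on each core. They also leave open whether a longer chain in the core would give a step closer to the first or to the second.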